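Replacing the Primary Carboxamide of Compound 1 with a Methylpiperazine Amide

The source may hold more compounds than are shown below. What is called first, only, known or untested is meant among the compounds shown, and "the series" means these compounds.

Measured compounds:
- compound 1, `COc1ccc(Cl)cc1S(=O)(=O)Nc1cncc(C(N)=O)c1`: 16 nM
- compound 2, `COc1ccc(OC(F)(F)F)cc1S(=O)(=O)Nc1cncc(C(N)=O)c1`: 131 nM
- compound 3, `COc1ccc(F)cc1S(=O)(=O)Nc1cncc(C(N)=O)c1`: 19 nM

Of the compounds shown here, three have been measured in an assay on isolated protein for inhibition of alkaline phosphatase, tissue-nonspecific isozyme (Homo sapiens); a higher number here means a weaker inhibitor, a lower number a stronger inhibitor. Compound 1 gives the lowest number of the three; compound 3 is nearest to it, and compound 2 is furthest away. The step of a 1.2-fold higher number from compound 1 to compound 3 (0.07 log units; within the scatter) lies within the scatter, so compound 1 and compound 3 cannot be ordered against each other. The steps of an 8.2-fold higher number from compound 1 to compound 2 (0.91 log units; beyond the scatter) and a 6.9-fold lower number from compound 2 to compound 3 (0.84 log units; beyond the scatter) are both beyond the scatter, and both concern only the substituent on the aromatic ring of the shared core.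

Compound 4, `COc1ccc(Cl)cc1S(=O)(=O)Nc1cncc(C(=O)N2CCN(C)CC2)c1`, differs from compound 1 in another place altogether: 4-methylpiperazin-1-yl in place of amino on a carbonyl carbon. None of the measured steps touches the carbonyl carbon, so none of them bears directly on this change, and no comparator exists for an amide of this kind in this assay. The expectation can therefore rest only on the size of the change counted above, which is larger than any of the measured changes. A modest weakening is expected, with wide uncertainty: the step of a 5.0-fold higher number from compound 1 to compound 4 (0.70 log units; beyond the scatter) is the estimate. Compound 4 is expected to give about 80 nM in this assay, within a range from 12 nM to 600 nM.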

Compound 4, half-maximal inhibitory concentration: 671 nM
The estimate for compound 4 lay 8.4-fold (0.92 log units) below the measured number; the whole stated range lies below it.
By their numbers in this assay, from the lowest: compounds 1 and 3 (each within the scatter of the next); then compound 2; then compound 4.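

In this assay the carbonyl carbon proves to be a place where the number responds strongly to change: the step of a 42-fold higher number from compound 1 to compound 4 (1.62 log units; beyond the scatter) is larger than the widest step among the aromatic substituents, an 8.2-fold higher number from compound 1 to compound 2 (0.91 log units; beyond the scatter) on the same core. The earlier compounds shown here all carry the carbamoyl group, so they said nothing about this place; the new step shows that, with chloro on the aromatic ring, (4-methylpiperazin-1-yl)carbonyl in place of carbamoyl gives a much weaker inhibitor. No measurement at hand bears on what lies behind this loss.

Going by these compounds, a single replacement cannot separate the parts of the change, so it remains open whether a simple methylamide, a dimethylamide or a morpholine amide would fall close to compound 1 or close to compound 4, and whether a carboxylic acid or a nitrile would be accepted on the aromatic carbon in place of the carbamoyl group. On these data alone, it also remains open whether the same replacement would cost as much with fluoro or trifluoromethoxy on the aromatic ring in place of chloro.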